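Bromo to methyl on the shared core

The source may hold more compounds than are shown below. What is called first, only, known or untested is meant among the compounds shown, and "the series" means these compounds.

Within the data shown here, in an ADME assay on microsomes from liver (Homo sapiens) for metabolic stability, using NADPH, with a stated time of 40 min, tested at 2 uM (on this read-out higher numbers stand for a longer-lived compound and lower numbers for a shorter-lived compound), three compounds have numbers so far. Compound 1 `Cc1cccc2c(-c3ccc4cccc(F)c4n3)c[nH]c12` gives 0.983 h, compound 3 `Cc1cc(F)cc2c(-c3ccc4ccccc4n3)c[nH]c12` gives 1.1 h, and compound 2 `Cc1cccc2c(-c3ccc4cccc(Br)c4n3)c[nH]c12` gives 2.4 h. Compound 2 stands highest of the three, and its gap to each of the others lies beyond the scatter.

The next compound is compound 4 `Cc1cccc2ccc(-c3c[nH]c4c(C)cccc34)nc12`, reached from compound 2 by one change: methyl in place of bromo on an aromatic carbon. In words, this is methyl in place of bromo on an aromatic carbon.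

Among the measured compounds shown here, one measured step bears on this carbon: a 2.4-fold higher number from compound 1 to compound 2 (0.39 log units; beyond the scatter), a modest step for bromo in place of fluoro. For the measured compounds named here, compound 3 has no group there and differs elsewhere as well, so it provides no clean step. Going by the values given here, no measured compound carries methyl at this carbon, which leaves the size of the change poorly fixed. Among the compounds with values here, compound 2 is also the only measured compound with bromo, and the two without it both sit lower, so a move to a lower number is expected, smaller than the measured step. The estimated step is a 1.7-fold lower number from compound 2 to compound 4 (0.23 log units; within the scatter). For compound 4 the estimated half-life is 1.4 h, with an expected range of 0.7 h to 2.8 h.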

Compound 4, half-life: 1.62 h
Compound 4: middle estimate off by 1.2-fold (0.06 log units), on the low side, and the stated range covers the measured number.
By their numbers in this assay, from the lowest: compounds 1, 3, 4 and 2 (each within the scatter of the next, the first and the last beyond it).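

Working notes on the aromatic carbon that carries fluoro, bromo or methyl on the shared core: in this assay this carbon now has three groups to compare, and methyl in place of bromo gives a 1.5-fold lower number from compound 2 to compound 4 (0.17 log units; within the scatter) as the reading for that change, while methyl in place of fluoro gives a 1.6-fold higher number from compound 1 to compound 4 (0.22 log units; within the scatter) as the reading for the other. Among these compounds, compound 4 therefore cannot be separated from either compound 1 or compound 2 on half-life, although a 2.4-fold higher number from compound 1 to compound 2 (0.39 log units; beyond the scatter) remains the one step at this carbon that clears the scatter, so methyl fills the gap between the two halogens without a distinct reading of its own. No measurement in hand accounts for any of these numbers, and the half-life differences at this carbon remain without an explanation.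

Still open, from the compounds shown here alone, is where an amine, a carboxylic acid, a methoxy group or a longer chain on this carbon would fall relative to the fluoro, methyl and bromo compounds. Also open, going by these compounds, is whether the same three groups would give the same small spread on another aromatic carbon of the shared core.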